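Phenyl to 4-fluorophenyl on the bromo compound

The source may hold more compounds than are shown below. What is called first, only, known or untested is meant among the compounds shown, and "the series" means these compounds.

Values so far in a functional assay on HepG2 cells (Homo sapiens) for inhibition, read by MTT assay, with a stated time of 48 h (a higher number here means a weaker inhibitor of growth, a lower number a stronger inhibitor of growth), for this series:
Compound 1 `Cn1cc(C2CC(c3ccccc3)=NN2C(=O)c2cccnc2)c2ccccc21` gives 4630 nM in this assay
Compound 2 `Cn1cc(C2CC(c3ccccc3)=NN2C(=O)c2cccnc2)c2cc(Br)ccc21` gives 2520 nM in this assay

Compound 2 and compound 1 lie within the scatter of each other, so these two numbers do not rank them. Compound 3 `Cn1cc(C2CC(c3ccc(F)cc3)=NN2C(=O)c2cccnc2)c2cc(Br)ccc21` differs from compound 2 by one change, phenyl to 4-fluorophenyl (fluoro in place of hydrogen on an aromatic carbon), which is fluoro in place of hydrogen on an aromatic carbon, para to a large group. For the measured compounds named here, only one measured step bears on this, and only loosely: a 1.8-fold lower number from compound 1 to compound 2 (0.26 log units; within the scatter) for bromo, not fluoro. Going by the values given here, no measured step covers fluoro here. On that single precedent, no step beyond the scatter is expected in this assay in either direction. The estimated step is a 1.1-fold lower number from compound 2 to compound 3 (0.02 log units; within the scatter) and is expected to stay within the scatter. For compound 3 the expected value is 2400 nM with an estimated range of 1100 nM to 5000 nM in this assay.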

Compound 3, concentration for 50% growth inhibition: 480 nM
For compound 3 the middle estimate is 5.0-fold (0.70 log units) above the measured one; the whole stated range lies above it.
By their numbers in this assay, from the lowest: compound 3; then compounds 2 and 1 (each within the scatter of the next).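

In this assay, for the compounds shown here, fluoro in place of hydrogen on the phenyl ring gives the first step in this short series that lies beyond the scatter (a 5.3-fold lower number from compound 2 to compound 3 (0.72 log units; beyond the scatter)), so this aromatic position can change the growth-inhibition read-out, at least with bromo present on the core. The earlier change, bromo in place of hydrogen at a different place on the core, could not show this, since its step lies within the scatter (a 1.8-fold lower number from compound 1 to compound 2 (0.26 log units; within the scatter)). No available evidence accounts for the effect of fluoro at this position.

From the compounds shown here alone, whether the step belongs to fluoro itself or would also appear with chloro, methyl or methoxy at the same carbon remains open. Also open, going by these compounds, is whether fluoro gives a step of this size on the core of compound 1, which carries hydrogen in place of bromo.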